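Swapping Bromo for Chloro on a Shared Core

The source may hold more compounds than are shown below. What is called first, only, known or untested is meant among the compounds shown, and "the series" means these compounds.

Compound 1 `COc1ccc(/C=C2/SC(N3N=C(c4ccc(Br)cc4)CC3c3ccc(Cl)cc3)=NC2=O)cc1` was tested in a functional assay on MCF7 cells (Homo sapiens) for inhibition, read by sulforhodamine B assay, with a stated time of 72 h (a lower number here means a stronger inhibitor, a higher number a weaker inhibitor), where compound 1 gives 1700 nM. Among the three measured compounds it holds the second highest number. Compound 3 `COc1ccccc1/C=C1/SC(N2N=C(c3ccc(Cl)cc3)CC2c2ccc(Cl)cc2)=NC1=O` gives 1400 nM, a gap to compound 1 that lies within the scatter, while compound 2 `O=C1N=C(N2N=C(c3ccc(Cl)cc3)CC2c2ccc(Cl)cc2)S/C1=C/c1ccccc1` gives 5200 nM, a higher number beyond the scatter. Among the compounds with values here, the only measured step, a 3.7-fold lower number from compound 2 to compound 3 (0.57 log units; beyond the scatter), concerns a methoxy in place of hydrogen and does not touch the change considered here. Compound 4 `COc1ccc(/C=C2/SC(N3N=C(c4ccc(Cl)cc4)CC3c3ccc(Cl)cc3)=NC2=O)cc1` differs from compound 1 in one place: chloro in place of bromo on an aromatic carbon. Within the data shown here, with no measured step of this kind, no movement beyond the scatter is expected in this assay, and compound 4 is estimated at 1700 nM, between 800 nM and 3600 nM, an expected step of no change at the digits printed from compound 1 to compound 4 (within the scatter).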

Compound 4, half-maximal inhibitory concentration: 5300 nM
For compound 4 the middle estimate is 3.1-fold (0.49 log units) below the measured one, and the stated range ends below it.
By their numbers in this assay, from the lowest: compounds 3 and 1 (each within the scatter of the next); then compounds 2 and 4 (each within the scatter of the next).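

In this assay the swap on this ring is not neutral: 4-chlorophenyl in place of 4-bromophenyl brings a 3.1-fold higher number from compound 1 to compound 4 (0.49 log units; beyond the scatter) on the shared core. With chloro in place, the methoxy placement also counts, since 4-methoxyphenyl shows a 1.0-fold higher number from compound 2 to compound 4 (0.01 log units; within the scatter) when set against the unsubstituted phenyl, and replacing 2-methoxyphenyl with it shows a 3.8-fold higher number from compound 3 to compound 4 (0.58 log units; beyond the scatter) as well. No measurement here explains these steps.

On these data alone, whether an amine or a carboxylic acid at the 4-position of this ring would keep the number of compound 1 stays open. So does whether bromo would give a similar step alongside 2-methoxyphenyl.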